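The source may report more compounds than this note shows. Statements on the series, on what has been measured and on what is new or still open speak of the compounds shown alone.

Compound 1 `CC(=O)c1cc(-c2ccc(F)cc2)cc2cc(-c3ccccc3)[nH]c12`, compound 2 `COc1ccc(-c2cc(C(C)=O)c3[nH]c(-c4ccccc4)cc3c2)cc1` and compound 3 `CC(=O)c1cc(-c2ccccc2)cc2cc(-c3ccc(F)cc3)[nH]c12` have been tested in a functional assay on MCF7 cells (Homo sapiens) for cytotoxicity, read by MTT assay, with a stated time of 2 days, tested at 1 uM; a lower number here means a stronger effect, a higher number a weaker effect of the compound at the concentration tested. In this assay compound 1 gives 82.7%, compound 2 gives 88.8% and compound 3 gives 96.8%. Compound 1 and compound 2 differ in a single place: methoxy in place of fluoro on an aromatic carbon That exchange produced a number 6.1 percentage points higher from compound 1 to compound 2 (within the scatter), so the two read-outs are effectively alike. The number for compound 3 lies within the scatter of that for compound 2 but beyond the scatter from that for compound 1. Compound 3 and compound 1 are built from the same atoms joined differently; the difference between the two cores is not broken down here.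

Compound 4 `COc1ccc(-c2cc3cc(-c4ccccc4)cc(C(C)=O)c3[nH]2)cc1` has not yet been measured. Within the data shown here, it differs from compound 3 in the same way that compound 2 differs from compound 1, at a position described in identical terms: methoxy in place of fluoro on an aromatic carbon Because the one earlier example of this exchange gave only a number 6.1 percentage points higher from compound 1 to compound 2 (within the scatter), a step of similarly small size is expected, a number 2.2 percentage points higher from compound 3 to compound 4 (within the scatter). That expectation rests on a single measured pair, and compound 3 already sits high in this assay, which leaves little room for a markedly higher number. Compound 4 is therefore estimated to give 99%, with a likely range from 89% to 108%.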

Compound 4, a percentage reported as activity, at one concentration (the size of the read-out at that concentration, not a potency): 78.1%
For compound 4 the middle estimate is 20.9 percentage points above the measured one; measured number outside the range, below it.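

In this assay, replacing the 4-fluorophenyl group with a 4-methoxyphenyl group on the core of compound 3 gives a number 18.7 percentage points lower from compound 3 to compound 4 (beyond the scatter), so here the methoxy compound has the stronger effect at the concentration tested. Set beside the earlier example, the result shows that this change does not carry over unaltered from one core to the other, since it shifts the read-out clearly on one core but not on the other: the same change on two cores in this assay, a number 6.1 percentage points higher (within the scatter) from compound 1 to compound 2 and a number 18.7 percentage points lower (beyond the scatter) from compound 3 to compound 4, 24.8 percentage points apart, beyond the scatter of two such steps The two cores are built from the same atoms joined differently, but two pairs cannot show which feature of the cores makes the change behave differently, nor which of the two behaviours would be more typical on a further core in this series.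

The compounds shown leave open how other groups would behave in the same place on each core, for example a hydroxyl group, an amine or a carboxylic acid in place of the fluoro or methoxy group. As far as these compounds go, it also remains open whether a longer chain in place of the methyl of the methoxy group would follow the trend of compound 4 or stay close to compound 3.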